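Cytotoxicity notes on the nitrobenzyl piperidine triazole series

The source may hold more compounds than are shown below. What is called first, only, known or untested is meant among the compounds shown, and "the series" means these compounds.

Compound 1 `O=[N+]([O-])c1ccc(CN2CCC(n3cc(CC(OCc4cc(-c5ccc(F)cc5)no4)c4ccc(Br)cc4)nn3)CC2)cc1` was run in an ADME assay on cells (Fibroblast, Homo sapiens) for cytotoxicity, with a stated time of 48 h; on this read-out higher numbers stand for weaker inhibition and lower numbers for stronger inhibition. In this assay compound 1 gives only a limit, > 25000 nM. Compound 2 `COc1cccc(-c2cc(COC(Cc3cn(C4CCN(Cc5ccc([N+](=O)[O-])cc5)CC4)nn3)c3ccc(Br)cc3)on2)c1` carries 3-methoxyphenyl in place of 4-fluorophenyl on an aromatic carbon. In this assay compound 2 likewise gives only a limit, > 25000 nM. The step that the two limits leave unreadable from compound 1 to compound 2 cannot be read because both values sit at the limit of > 25000 nM in this assay, at which 2 of the 2 values shown sit. Compound 3 `N#Cc1cccc(-c2cc(COC(Cc3cn(C4CCN(Cc5ccc([N+](=O)[O-])cc5)CC4)nn3)c3ccc(Br)cc3)on2)c1` differs from compound 1 by 3-cyanophenyl in place of 4-fluorophenyl on an aromatic carbon. Going by the values given here, the only measured step that bears on this change is the one from compound 1 to compound 2, and its size is not readable, so no step beyond the scatter is expected in this assay in either direction. Compound 3 is expected to give 30000 nM (range 10000 nM to 100000 nM), most likely again reported as a limit. For compound 3 the step that the limit leaves unreadable from compound 1 to compound 3 is estimated to lie within the scatter.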

Compound 3, half-maximal inhibitory concentration: > 25000 nM
Compound 3 ended at the assay's limit (the forecaster's own chance of this, stated with the estimate: 85%); the middle value is on the limit's open side.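

Going by these compounds alone, compound 3, like compound 1 and compound 2, is reported only as a limit, so no step among the three can be read: the limit of > 25000 nM in this assay, at which 3 of the 3 values shown sit.

The compounds shown leave open whether 4-fluorophenyl, 3-methoxyphenyl and 3-cyanophenyl differ at all in this assay.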